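From Aminomethyl to Hydroxymethyl at the Assay Limit

A few compounds are considered here, and "the series" means these few. Any claim that something is new, unique, unknown or untested is made for them only; others in the source may bear on it.

In a functional assay on CCRF-CEM cells (Homo sapiens) for antiproliferative activity, with a stated time of 72 h (a higher number here means that more compound is needed for the effect, a lower number that less compound is needed), compound 1 `Cc1cn([C@@H]2O[C@H](CO)[C@@H](CN)[C@H]2O)c(=O)[nH]c1=O` gives > 100 uM, which is a limit and not a number. Compound 2 `Cc1cn([C@@H]2O[C@H](CO)[C@@H](CN)[C@@H]2O)c(=O)[nH]c1=O` gives > 100 uM, also a limit. Among the compounds with values here, the only measured step, a step that the two limits leave unreadable from compound 1 to compound 2, changes configuration alone and has no readable size. Compound 3 `Cc1cn([C@@H]2O[C@H](CO)[C@@H](CO)[C@H]2O)c(=O)[nH]c1=O` carries hydroxy in place of amino on a saturated chain carbon bound to a saturated ring carbon. Within the data shown here, no measured step covers this swap, so no change beyond the scatter is expected in this assay. The estimated step is a step that the limit leaves unreadable from compound 1 to compound 3. For compound 3 the expected value is 150 uM, with an estimated range of 50 uM to 500 uM.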

Compound 3, concentration for half-maximal effect: > 100 uM
Compound 3 ended at the assay's limit; the forecaster's own chance of this, stated with the estimate: 85%; the middle value does not contradict the limit.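

The values of compound 1 and compound 3 are both limits and not numbers, so no step between them can be read: the limit of > 100 uM in this assay, at which 3 of the 3 values shown sit.

The compounds shown leave open how much of each is needed in this assay, and so whether hydroxy in place of amino changes anything.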